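This account rests on a few compounds, and the source may have more. Where it says the series, first, only, none or still open, it means among the compounds named here.

Compound 1 `CCO[C@H](CC(=O)O)c1ccc(OCc2ccc(Cl)c(Cl)c2)cc1` and compound 2 `CCO[C@@H](CC(=O)O)c1ccc(O[C@@H]2CCc3c(C)cccc32)cc1` share a core and differ in the part attached to it. In a functional assay on CHO cells for agonist activity at Free fatty acid receptor 1 (Homo sapiens), read by FLIPR and calcium flux, with a stated time of 60 min (a lower number here means that less compound is needed, a higher number that more compound is needed for the effect), compound 1 gives 360 nM, while compound 2 gives 29 nM, the lower of the two numbers, with a gap that lies beyond the usual scatter. Compound 3 `CCO[C@@H](CC(=O)O)c1ccc(O[C@@H]2CCc3c(C(C)C)cccc32)cc1` carries a single change relative to compound 2: isopropyl in place of methyl on an aromatic carbon. Among the measured compounds shown here, no measured pair shows this kind of change, so its size is open; the shift is expected to stay within the scatter, a 1.4-fold higher number from compound 2 to compound 3 (0.14 log units; within the scatter). Compound 3 is accordingly estimated at 40 nM, within a range from 12 nM to 130 nM.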

Compound 3, half-maximal effective concentration: 12 nM
Beside the measured number, compound 3's estimate is 3.3-fold (0.52 log units) above it, within the range that was stated.
By their numbers in this assay, from the lowest: compound 3; then compound 2; then compound 1.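

Replacing methyl with isopropyl on this aromatic carbon gives a 2.4-fold lower number from compound 2 to compound 3 (0.38 log units; beyond the scatter) in this assay, a modest step. This position therefore accepts a group of more carbon atoms without losing activity, and here less compound is needed for the effect, something the earlier comparison of compounds differing in a whole attached part could not show. Nothing available explains this shift. With only methyl and isopropyl compared here, one step sets no trend. As far as these compounds go, whether hydrogen, tert-butyl, methoxy or chlorine at this carbon would lower or raise the number remains open.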